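Replacing cyclopentyl with 4-fluorocyclohexyl at a half-life limit

The source may report more compounds than this note shows. Statements on the series, on what has been measured and on what is new or still open speak of the compounds shown alone.

In an ADME assay on microsomes from liver (Homo sapiens) for metabolic stability, read by LC-MS, using NADPH, with a stated time of 45 min, tested at 3 uM (a lower number here means that the compound disappears faster, a higher number that the compound lasts longer), compound 1 `C1CCC(C(CC2CCCCN2)C2CCCC2)CC1` gives > 2.5 h, which is a limit of the assay and not a number. Compound 2 `C1CCC(CC(C2CCCC2)C2CCCC2)NC1` gives 0.833 h in this assay. For the measured compounds named here, the one measured step that bears on the change is an at least 3.0-fold lower number from compound 1 to compound 2 (0.47 log units; beyond the scatter), with cyclopentyl in place of cyclohexyl. Compound 3 `FC1CCC(C(CC2CCCCN2)C2CCCCC2)CC1` carries 4-fluorocyclohexyl in place of cyclopentyl on a saturated chain carbon bound to a saturated chain carbon and a saturated ring carbon. Here cyclopentyl leaves and a six-membered ring enters, so no fall beyond the scatter is expected. The expected change is a step that the limit leaves unreadable from compound 1 to compound 3. For compound 3, the estimated half-life is 2.8 h, with an expected range of 1.3 h to 6 h.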

Compound 3, half-life: 1.08 h
Compound 3: middle estimate off by 2.6-fold (0.41 log units), on the high side; measured number outside the range, below it.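

In this assay the step at this place is an at least 2.3-fold lower number from compound 1 to compound 3 (0.36 log units; beyond the scatter), so a six-membered ring entering for cyclopentyl does not keep the number of compound 1. Together with the earlier step, both changes shown from compound 1 now lower the number, one bringing in cyclopentyl and one removing it. Compound 1 gives > 2.5 h, which is a limit of the assay and not a number: the limit of > 2.5 h in this assay, at which 1 of the 3 values shown sits.

From the compounds shown here alone, whether the fall follows the fluorine or the ring itself stays open. Plain cyclohexyl at this place, or 4-methoxycyclohexyl, would bear on that.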